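From methoxycarbamoyl to carbamoyl, without a starting number

A few compounds are considered here, and "the series" means these few. Any claim that something is new, unique, unknown or untested is made for them only; others in the source may bear on it.

In a functional assay on MCF7 cells (Homo sapiens) for antiproliferative activity, with a stated time of 72 h (a lower number here means that less compound is needed, a higher number that more compound is needed for the effect), compound 1 (`O=C(NO)c1ccc(N(Cc2ccc(C3CCCCC3)cc2)C(=O)[C@H]2CCN2S(=O)(=O)c2c(F)c(F)c(F)c(F)c2F)cc1`) gives 6800 nM. Compound 2 (`O=C(NO)c1ccc(N(Cc2ccc(C3CCOCC3)cc2)C(=O)[C@H]2CCN2S(=O)(=O)c2c(F)c(F)c(F)c(F)c2F)cc1`) gives > 10000 nM, which is a limit of the assay and not a number. Among the compounds with values here, the only measured step, an at least 1.4-fold higher number from compound 1 to compound 2 (0.16 log units; that floor lies within the scatter), places oxan-4-yl in place of cyclohexyl on an aromatic carbon. Compound 3 (`CONC(=O)c1ccc(N(Cc2ccc(C3CCCCC3)cn2)C(=O)[C@H]2CCN2S(=O)(=O)c2c(F)c(F)c(F)c(F)c2F)cc1O`) offers no starting point, since the result in this assay for compound 3 is "not determined" (no result reported). Compound 4 (`NC(=O)c1ccc(N(Cc2ccc(C3CCCCC3)cn2)C(=O)[C@H]2CCN2S(=O)(=O)c2c(F)c(F)c(F)c(F)c2F)cc1O`) differs from compound 3 by hydrogen in place of methoxy on an amide-type nitrogen, turning methoxycarbamoyl into carbamoyl. The measured step involves a different change at a different place, so it does not bear directly on this one. No size or direction of step can therefore be expected in this assay. The remaining guide is the general level set by compound 1 at 6800 nM. The expected value for compound 4 is 9000 nM, with an estimated range from 2500 nM to 30000 nM.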

Compound 4, half-maximal effective concentration: 4600 nM
Estimate against measurement, compound 4: 2.0-fold (0.29 log units) above; the measured number falls inside the stated range.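

In this assay compound 3 has no result, so no new step can be read for compound 4, which differs from it in one place. The compounds shown leave open how the change from methoxycarbamoyl to carbamoyl moves the number. Nothing shown here bears on the result for compound 4.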